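The compounds below may be only part of what the source reports. "The series", "measured", "known", "first", "only" and "open" are said of these compounds alone.

Measured compounds:
compound 1, `COc1cc(C(=O)NS(=O)(=O)c2cc(C)ccc2C)ccc1Cn1ccc2ccc(NC(=O)CC3CCCC3)cc21`: 8.4
compound 2, `CCCCC(CC)C(=O)Nc1ccc2ccn(Cc3ccc(C(=O)NS(=O)(=O)c4ccccc4)cc3)c2c1`: 6.8
compound 3, `COc1cc(C(=O)NS(=O)(=O)c2ccccc2)ccc1Cn1ncc2ccc(NC(=O)CC3CCCC3)cc21`: 10.5

All three numbers come from a functional assay (trachea) for antagonist activity, with Cavia porcellus as the target; on this read-out lower numbers stand for lower potency and higher numbers for higher potency (the scale is a negative logarithm). Compound 1 stands second highest of the three. Its nearest neighbour is compound 2, which lies lower by a gap beyond the usual scatter of repeated measurements; the furthest is compound 3, which lies higher, again by a gap beyond the scatter. No two of the measured compounds differ in only one place, so none of these gaps can be tied to a single structural change: compound 2 and compound 3 each differ from compound 1 in the amide, in the core or in the substitution of the benzyl ring as well as at the sulfonyl-bound ring.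

Compound 4, `COc1cc(C(=O)NS(=O)(=O)c2ccccn2)ccc1Cn1ccc2ccc(NC(=O)CC3CCCC3)cc21`, is the one-place variant of compound 1 now to be measured: pyridin-2-yl in place of 2,5-dimethylphenyl on a sulfonyl sulfur. Compounds 2 and 3 carry a plain phenyl on the sulfonyl sulfur. They differ from compound 1 in more than one place and offer no clean reading of that position. A modest step downward, a number 0.40 log units lower from compound 1 to compound 4 (beyond the scatter), is expected for compound 4 in this assay, of a size near the edge of the scatter. Compound 4 is estimated at 8, with a range from 7.2 to 8.8.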

Compound 4, negative logarithm of the antagonist equilibrium constant: 8.9
Compound 4: middle estimate off by 0.90 log units, on the low side; measured number above the stated range.
By their numbers in this assay, from the lowest: compound 2; then compound 1; then compound 4; then compound 3.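

Pyridin-2-yl in place of 2,5-dimethylphenyl on a sulfonyl sulfur gives the first clean reading of this position in this assay and amounts to a number 0.50 log units higher from compound 1 to compound 4 (beyond the scatter) with the rest of the compound unchanged. This step is modest but beyond the scatter, and it shows that the dimethyl-substituted carbon ring is not required to hold the number of compound 1 on this core: a ring with a hetero atom and a hydrogen-bond acceptor gives a higher number here. Nothing at hand bears on the reason for this rise.

For the compounds shown here, the single step combines loss of both methyl groups with entry of the ring nitrogen, so the share of each stays open, and the earlier plain phenyl compounds cannot settle this, as each differs from compound 1 in other places too. Also open, as far as these compounds go, are how a plain phenyl, a pyridin-3-yl or a thiophen-2-yl group on the same sulfonyl sulfur of compound 1 would read in this assay and whether the step from 2,5-dimethylphenyl to pyridin-2-yl carries over to other cores.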